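The source may report more compounds than this note shows. Statements on the series, on what has been measured and on what is new or still open speak of the compounds shown alone.

In an ADME assay on WI-38 cells (Homo sapiens) for cytotoxicity, read by sulforhodamine B assay, with a stated time of 24 h (on this read-out higher numbers stand for weaker inhibition and lower numbers for stronger inhibition), compound 1 `N#CCC(=O)N/N=C1\C(=O)Nc2ccc(S(=O)(=O)N3CCOCC3)cc21` gives 302000 nM while compound 2 `O=C1Nc2ccc(S(=O)(=O)N3CCOCC3)cc2/C1=N/c1ccc(O)cc1` gives 259000 nM and compound 3 `O=C1Nc2ccc(S(=O)(=O)N3CCOCC3)cc2/C1=N/Nc1ccccc1` gives 262000 nM on the same read-out. The steps of a 1.2-fold lower number from compound 1 to compound 3 (0.06 log units; within the scatter) and a 1.0-fold higher number from compound 2 to compound 3 (0.01 log units; within the scatter) both lie within the usual scatter, so compound 3 stands together with the other two and no order can be read among them.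

Compound 4 `O=C1Nc2ccc(S(=O)(=O)N3CCOCC3)cc2/C1=N/c1ccc(Cl)cc1` is still unmeasured and differs from compound 3 in one place, where 4-chlorophenyl comes in place of anilino on a double-bonded nitrogen (4-chlorophenyl in place of anilino on a double-bonded nitrogen). Changes of the group on this nitrogen have so far been small, with a 1.2-fold lower number from compound 1 to compound 2 (0.07 log units; within the scatter) and a 1.0-fold higher number from compound 2 to compound 3 (0.01 log units; within the scatter) as the measured cases. Among the compounds with values here, none of the measured compounds carries chlorine, so the entering group itself is untested here. The expected step is therefore none beyond the scatter, with a 1.1-fold lower number from compound 3 to compound 4 (0.04 log units; within the scatter) as its estimated size. For compound 4 the estimated value is 240000 nM within an expected range from 130000 nM to 400000 nM for repeat measurements.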

Compound 4, half-maximal inhibitory concentration: 468000 nM
Beside the measured number, compound 4's estimate is 2.0-fold (0.29 log units) below it; measured number above the stated range.
By their numbers in this assay, from the lowest: compounds 2, 3, 1 and 4 (each within the scatter of the next).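

The steps of a 1.8-fold higher number from compound 3 to compound 4 (0.25 log units; within the scatter) and a 1.8-fold higher number from compound 2 to compound 4 (0.26 log units; within the scatter) and a 1.5-fold higher number from compound 1 to compound 4 (0.19 log units; within the scatter) show that in this assay a group carrying chlorine on the double-bonded nitrogen cannot be told apart from the three groups seen before. This holds for 4-chlorophenyl, with no hydrogen-bond donor or acceptor, set against anilino, which has one of each, and it also holds where chloro stands in place of hydroxy on an aromatic carbon. No supporting measurement bears on these numbers.

On these data alone, whether an amine or a carboxylic acid on the aromatic ring, or a longer chain on this nitrogen, would give a step beyond the scatter remains open. All four compounds share the same core, so the effect of changes elsewhere on it is also unknown.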